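Swapping dimethylamino in compound 2: what happens to clearance?

This account rests on a few compounds, and the source may have more. Where it says the series, first, only, none or still open, it means among the compounds named here.

- compound 1 `CNc1nc(NC2(C#N)CCCCCC2)nc(-n2cncn2)n1`: 276 mL/min/kg
- compound 2 `CNc1nc(NC2(C#N)CCCCC2)nc(N(C)C)n1`: 276 mL/min/kg
- compound 3 `CNc1nc(NC2(C#N)CCCC2)nc(-n2cncn2)n1`: 43 mL/min/kg

These numbers come from an ADME assay on microsomes from liver (Rattus norvegicus) for metabolic stability; on this read-out higher numbers stand for fast clearance and lower numbers for slow clearance. Compound 2 gives 276 mL/min/kg, level with compound 1, and the two share the top of this small set. Compound 3 gives 43 mL/min/kg, clearly lower and beyond the scatter.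

The next molecule, compound 4 `CNc1nc(NC2(C#N)CCCCC2)nc(-n2cnc(C)n2)n1`, has not been measured yet. It carries 3-methyl-1H-1,2,4-triazol-1-yl in place of dimethylamino on an aromatic carbon.

Among the compounds with values here, no measured pair isolates this change. The nearest guide is the same ring without its methyl, found in two compounds that also differ elsewhere. Compound 1 shows 276 mL/min/kg with that ring, and compound 3 shows 43 mL/min/kg. The ring alone therefore settles little, and a value between these two seems the fair expectation. The expected change is a modest drop, a 2.3-fold lower number from compound 2 to compound 4 (0.36 log units; beyond the scatter). For compound 4 the estimated clearance is 120 mL/min/kg, with an expected range of 40 mL/min/kg to 280 mL/min/kg.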

Compound 4, clearance: > 276 mL/min/kg
Compound 4: a limit, no number (the forecaster's own chance of this, stated with the estimate: 5%); middle value at least 2.3-fold (0.36 log units) from the limit.
By their numbers in this assay, from the lowest: compound 3; then compounds 1 and 2 (each within the scatter of the next).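

In this assay, putting 3-methyl-1H-1,2,4-triazol-1-yl in place of dimethylamino on this aromatic carbon gives a number no lower from compound 2 to compound 4 (the limit leaves the size open). Within the data shown here, this is the first view of this position with the rest of compound 2 held fixed, and it shows that this swap does not bring clearance down. The result for compound 4 is a limit of the assay and not a number: the limit of > 276 mL/min/kg in this assay, at which 1 of the 4 values shown sits.

Going by these compounds, how far compound 4 lies from compound 2 therefore stays unknown, so the size of the change remains open. The compounds shown also leave open whether another group on this aromatic carbon, such as a methoxy group or a morpholine ring, would give lower clearance with the rest of compound 2 unchanged.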